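Shortening the acyl chain on a triazene amide series

The compounds below may be only part of what the source reports. "The series", "measured", "known", "first", "only" and "open" are said of these compounds alone.

Measured so far:
Compound 1, `CC(=O)N[C@@H](C)C(=O)N(C)/N=N/c1ccc(C(N)=O)cc1`: 7.6 h
Compound 2, `CCOC(=O)c1ccc(/N=N/N(C)C(=O)[C@H](C)NC(C)=O)cc1`: 4.6 h
Compound 3, `CCCC(=O)N[C@@H](C)C(=O)N(C)/N=N/c1ccc(C#N)cc1`: 1.1 h

In an ADME assay on a cell-free system (plasma, Homo sapiens) for metabolic stability, read by HPLC (a higher number here means that the compound lasts longer, a lower number that the compound disappears faster), compound 3 gives the lowest of the three numbers; its gap to compound 2 and its larger gap to compound 1 both lie beyond the scatter. Compound 4, `CC(=O)N[C@@H](C)C(=O)N(C)/N=N/c1ccc(C#N)cc1`, is not yet measured. It differs from compound 3 in one place: hydrogen in place of ethyl on a saturated chain carbon bound to a carbonyl carbon. For the measured compounds named here, only one measured step exists, a 1.7-fold lower number from compound 1 to compound 2 (0.22 log units; within the scatter), and it concerns the group on the aromatic ring, not the acyl chain, so it does not bear on this change. Compounds 1 and 2, which carry the acetamido group that compound 4 will also carry, both gave higher numbers than compound 3, but they differ from compound 4 at the aromatic end as well, so the comparison is indirect. The step is therefore expected to be a 2.7-fold higher number from compound 3 to compound 4 (0.44 log units; beyond the scatter), with wide uncertainty. For compound 4 the estimate is 3 h, between 1 h and 9 h.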

Compound 4, half-life: 1 h
For compound 4 the middle estimate is 3.0-fold (0.48 log units) above the measured one; measured number inside the range.
By their numbers in this assay, from the lowest: compounds 4 and 3 (each within the scatter of the next); then compounds 2 and 1 (each within the scatter of the next).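

In this assay, acetyl in place of propylcarbonyl on the cyano-bearing core gives a 1.1-fold lower number from compound 3 to compound 4 (0.04 log units; within the scatter) and so, for this pair, shortening the chain at this position from propyl to methyl leaves the number within the scatter. With the acetamido end now held constant, the aromatic group can be compared directly: cyano in place of ethoxycarbonyl gives a 4.6-fold lower number from compound 2 to compound 4 (0.66 log units; beyond the scatter) and cyano in place of carbamoyl gives a 7.6-fold lower number from compound 1 to compound 4 (0.88 log units; beyond the scatter), which places the larger differences among these compounds at the aromatic group, not the acyl chain.

From the compounds shown here alone, whether the chain change would also stay within the scatter with carbamoyl or ethoxycarbonyl on the ring remains open, as does the outcome for a longer chain, an amine at this position or a carboxylic acid on the ring. Nothing available here accounts for the lower numbers seen with cyano.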